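This account rests on a few compounds, and the source may have more. Where it says the series, first, only, none or still open, it means among the compounds named here.

Measured so far in a functional assay on NCI-H460 cells (Homo sapiens) for inhibition, tested at 10 uM; a lower number here means less inhibition, a higher number more inhibition at the concentration tested (going by the name of the read-out):
- compound 1 `CC(=O)Nc1ccc(S(=O)(=O)NNC(=O)c2cccnc2Nc2ccc(Cl)cc2)cc1`: 31%
- compound 2 `COc1ccc(Nc2ncccc2C(=O)NNS(=O)(=O)c2ccc(C)cc2)cc1`: 84%
- compound 3 `O=C(NNS(=O)(=O)c1ccc(F)cc1)c1cccnc1Nc1ccc(Cl)cc1Cl`: 0%

Compound 1 stands second highest of the three numbers in this assay. Compound 3 lies below it, beyond the scatter; compound 2 lies above it, also beyond the scatter. Compound 4 `O=C(NNS(=O)(=O)c1ccc(Cl)cc1Cl)c1cccnc1Nc1ccc(Cl)cc1` has not yet been measured. It differs from compound 1 in one place: 2,4-dichlorophenyl in place of 4-acetamidophenyl on a sulfonyl sulfur. Within the data shown here, no pair of measured compounds shows this change alone, so there is no measured step to lean on; the three values themselves vary widely with the groups on the sulfonyl sulfur and on the anilino ring. The expected step in this assay is a number 9 percentage points lower from compound 1 to compound 4 (within the scatter), a modest lowering that may well stay within the scatter. Compound 4 is therefore estimated at 22%, with a range from 0% to 55%.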

Compound 4, a percentage reported as inhibition, at one concentration (the size of the read-out at that concentration, not a potency): 1%
The estimate for compound 4 lay 21 percentage points above the measured number, and the stated range covers the measured number.
By their numbers in this assay, from the lowest: compounds 3 and 4 (each within the scatter of the next); then compound 1; then compound 2.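

In this assay, a change on a sulfonyl sulfur can now be read on its own, with the rest of the core held constant: a number 30 percentage points lower from compound 1 to compound 4 (beyond the scatter) when 2,4-dichlorophenyl replaces 4-acetamidophenyl. This position therefore moves the read-out independently of the anilino ring. Nothing available explains the step. Still open, as far as these compounds go, is how a carboxylic acid or an amine on the phenyl ring at this position would read, and whether the same change gives a similar step on the core of compound 2.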